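Butyl in Place of Phenylsulfinyl on a Phosphate-Bearing Core

The compounds below may be only part of what the source reports. "The series", "measured", "known", "first", "only" and "open" are said of these compounds alone.

Compound 1 `COC(=O)Nc1nc2cc([S+]([O-])c3ccccc3)ccc2n1COP(=O)(O)O` was examined in a physicochemical assay for solubility, at pH 7.4; on this read-out higher numbers stand for higher solubility and lower numbers for lower solubility. In this assay compound 1 reached only the limit of > 50000000 nM, which is a limit of the assay and not a number. Compound 2 `COC(=O)Nc1nc2cc(C(=O)c3ccc(F)cc3)ccc2n1COP(=O)(O)O` carries a fluorobenzoyl group on the same core, and in this assay compound 2 likewise gave > 50000000 nM, again a limit. Compound 3 `COC(=O)Nc1nc2cc(S(=O)(=O)Oc3ccc(F)cc3)ccc2n1COP(=O)(O)O`, with a fluorophenyl sulfonate ester, also gave > 50000000 nM in this assay, once more a limit. For the measured compounds named here, the step that the two limits leave unreadable from compound 1 to compound 2 therefore cannot be sized, because the limit of > 50000000 nM in this assay, at which 3 of the 3 values shown sit, marks where every value so far sits.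

Compound 4 `CCCCc1ccc2c(c1)nc(NC(=O)OC)n2COP(=O)(O)O` differs from compound 1 as follows: a group of 4 heavy atoms (4 carbon; no ring) in place of a group of 8 heavy atoms (6 carbon, 1 oxygen, 1 sulfur; one six-membered aromatic ring of carbon only), on an aromatic carbon. Going by the values given here, no measured step reads on this change, since the only step recorded on the series is the unreadable one from compound 1 to compound 2. With every value in the set resting on the limit, the expectation for compound 4 is that its solubility again lies at or around that limit, and the step that the limit leaves unreadable from compound 1 to compound 4 is expected to be small or not resolvable. Compound 4 is therefore estimated at 60000000 nM, within a range from 10000000 nM to 300000000 nM.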

Compound 4, solubility: > 50000000 nM
Compound 4: no number, only a limit; the forecaster's own chance of this, stated with the estimate: 75%; the middle value is on the limit's open side.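

In this assay, for the compounds shown here, compound 4 also rests on a limit and not a number, so no step from compound 1 or compound 2 to compound 4 can be read: the limit of > 50000000 nM in this assay, at which 4 of the 4 values shown sit. The compounds shown leave open how compound 1, compound 2, compound 3 and compound 4 compare in solubility beyond that limit.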